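The compounds below may be only part of what the source reports. "The series", "measured", "known", "first", "only" and "open" are said of these compounds alone.

Working notes on the series. The shared core is that of compound 1, `COc1ccc(C(=O)/C=C/c2ccc(C(=O)O)cc2)c(O)c1`. In an ADME assay on SH-SY5Y cells (Homo sapiens) for cytotoxicity, read by MTT assay, with a stated time of 48 h (on this read-out higher numbers stand for weaker inhibition and lower numbers for stronger inhibition), compound 1 returns only a limit, > 100000 nM. Compound 2, `CCOCCCOc1ccc(/C=C/C(=O)c2ccc(OC)cc2O)cc1OC`, is a second member of the set; in this assay compound 2 likewise stops at a limit, > 100000 nM. Compound 3, `COc1ccc(C(=O)/C=C/c2ccc(C(=O)Nc3ccccc3OC)cc2)c(O)c1`, carries (2-methoxyphenyl)amino in place of hydroxy on a carbonyl carbon; in this assay compound 3 also gives no more than a limit, > 100000 nM. Going by the values given here, the one change at that position that has been measured reads a step that the two limits leave unreadable from compound 1 to compound 3, so its size stays unknown. All three values sit at the same place: the limit of > 100000 nM in this assay, at which 3 of the 3 values shown sit.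

Compound 4, `COc1ccc(C(=O)/C=C/c2ccc(C(=O)NC(C)C)cc2)c(O)c1`, is not yet measured. Against compound 1 it shows (isopropylamino in place of hydroxy on a carbonyl carbon). The step from compound 1 to compound 3 is the only measured one at this position and carries no readable size, so no change beyond the scatter is expected in this assay. For compound 4 the expected outcome in this assay is another limit, with an estimate of 150000 nM and a range of 50000 nM to 500000 nM. The step this estimate implies, a step that the limit leaves unreadable from compound 1 to compound 4, is expected to lie within the scatter.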

Compound 4, half-maximal inhibitory concentration: > 100000 nM
Compound 4 ended at the assay's limit; the forecaster's own chance of this, stated with the estimate: 80%; the middle value is on the limit's open side.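

Compound 4 also returns only a limit, so its steps from compound 1 and from compound 3 cannot be read: the limit of > 100000 nM in this assay, at which 4 of the 4 values shown sit. The compounds shown leave open whether any replacement on the carbonyl carbon gives a readable value in this assay, and how large such a step would be.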